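A few compounds are considered here, and "the series" means these few. Any claim that something is new, unique, unknown or untested is made for them only; others in the source may bear on it.

Measured so far:
- compound 1, `Nc1nc(-c2ccccc2)cc(-c2cnn(-c3ccccc3)n2)n1` — a limit of the assay: > 200000 nM
- compound 2, `Nc1nc(-c2ccc([N+](=O)[O-])cc2)cc(-c2cnn(-c3ccccc3)n2)n1` — 132000 nM

For the measured compounds named here, in a functional assay on SNB-19 cells (Homo sapiens) for inhibition, read by MTT assay (on this read-out higher numbers stand for weaker inhibition and lower numbers for stronger inhibition), compound 2 gives 132000 nM, the only number. Compound 1 sits at the limit of > 200000 nM in this assay, at which 1 of the 2 values shown sits. Going by the values given here, the sole measured step, an at least 1.5-fold lower number from compound 1 to compound 2 (0.18 log units; that floor lies within the scatter), came with nitro in place of hydrogen on an aromatic carbon, and its floor lies within the scatter, so even that step carries little weight.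

Compound 3, `Nc1ccc(-c2cc(-c3cnn(-c4ccccc4)n3)nc(N)n2)cc1`, differs from compound 2 by amino in place of nitro on an aromatic carbon. Among the compounds with values here, no measured step covers amino in place of nitro; the step from compound 1 to compound 2 concerns the same position but a different group, and its size is uncertain. With nothing bearing directly on the exchange, the working expectation for compound 3 is no step beyond the scatter, that is a 1.1-fold lower number from compound 2 to compound 3 (0.04 log units; within the scatter). Compound 3 is therefore estimated at 120000 nM in this assay, with a range from 30000 nM to 400000 nM, and a fair chance that only a limit is reported.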

Compound 3, half-maximal inhibitory concentration: 107000 nM
Compound 3: middle estimate off by 1.1-fold (0.05 log units), on the high side, and the stated range covers the measured number.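

In this assay, the exchange of 4-nitrophenyl for 4-aminophenyl gives a 1.2-fold lower number from compound 2 to compound 3 (0.09 log units; within the scatter), so this read-out does not separate these two groups at this position, even though they differ in heavy atoms and in hydrogen-bond donors and acceptors. Amino in place of hydrogen gives an at least 1.8-fold lower number from compound 1 to compound 3 (0.27 log units; that floor lies within the scatter), and like the nitro step this is a floor within the scatter, so neither group is yet shown to shift the number from that of the hydrogen. Compound 1 stands as a limit of the assay, and both steps from it remain floors because of where it sits: the limit of > 200000 nM in this assay, at which 1 of the 3 values shown sits.

Still open, from the compounds shown here alone, is whether any group on this aromatic carbon moves the number beyond the scatter, and a carboxylic acid, a methoxy group or an acetamide there would put that to the test. Equally open, going by these compounds, is whether a change elsewhere on the shared core, such as a chlorine in place of a hydrogen, would do more than either change at this position.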